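A few compounds are considered here, and "the series" means these few. Any claim that something is new, unique, unknown or untested is made for them only; others in the source may bear on it.

In an ADME assay on microsomes from liver (Homo sapiens) for metabolic stability, with a stated time of 10 min (a higher number here means that more of the compound is left, a lower number that less of the compound is left), compound 3 (`O=C(O)[C@H]1CC[C@H](C(=O)N2CC[C@](c3ccc(C(OCc4ccccc4OC(F)(F)F)(C(F)(F)F)C(F)(F)F)cc3)(S(=O)(=O)c3ccc(F)cc3)C2)CC1`) gives 93%, the highest of the three numbers, while compound 2 (`CC(=O)N1CCC(O)(C(=O)N2CC[C@](c3ccc(C(OCc4c(F)cccc4F)(C(F)(F)F)C(F)(F)F)cc3)(S(=O)(=O)c3ccc(F)cc3)C2)CC1`) gives 16% and compound 1 (`CC(=O)N1CC[C@@H](C(=O)N2CC[C@](c3ccc(C(OCc4c(F)cccc4F)(C(F)(F)F)C(F)(F)F)cc3)(S(=O)(=O)c3ccc(F)cc3)C2)C1`) gives 9%. The gaps from compound 3 to each of the other two lie beyond the scatter. Compound 4 (`Cc1cccc(C)c1COC(c1ccc([C@]2(S(=O)(=O)c3ccc(F)cc3)CCN(C(=O)[C@H]3CC[C@H](C(=O)O)CC3)C2)cc1)(C(F)(F)F)C(F)(F)F`) differs from compound 3 in one place: 2,6-dimethylphenyl in place of 2-(trifluoromethoxy)phenyl on a saturated chain carbon bound to an oxygen on a saturated carbon. The same difference can be read as 2,6-dimethylbenzyl in place of 2-(trifluoromethoxy)benzyl. Among the compounds with values here, the only measured single-place step, a number 7 percentage points higher from compound 1 to compound 2 (within the scatter), concerns another part of the molecule and gives no direct guide to this change. The expectation therefore rests on compound 3 at 93%. The estimated step is a number 8 percentage points lower from compound 3 to compound 4 (within the scatter), so no change beyond the scatter is expected. For compound 4 the estimated value is 85%, with an expected range from 65% to 97%.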

Compound 4, percent of the compound remaining: 89%
Beside the measured number, compound 4's estimate is 4 percentage points below it; the measured number falls inside the stated range.
By their numbers in this assay, from the lowest: compounds 1 and 2 (each within the scatter of the next); then compounds 4 and 3 (each within the scatter of the next).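

In this assay, placing 2,6-dimethylphenyl where 2-(trifluoromethoxy)phenyl stood, on a saturated chain carbon bound to an oxygen on a saturated carbon, gives a number 4 percentage points lower from compound 3 to compound 4 (within the scatter). This position therefore tolerates the loss of the trifluoromethoxy group in this assay, at least in exchange for two methyl groups, with no change beyond the scatter. No available evidence explains this result. From the compounds shown here alone, whether a phenyl group carrying an amine or a nitrile would behave the same remains open, as does whether the position tolerates a longer chain.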